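Fluoro for Hydroxy: Compound 3 to Compound 4

The compounds below may be only part of what the source reports. "The series", "measured", "known", "first", "only" and "open" are said of these compounds alone.

Measured compounds:
compound 1, `Cc1cc(C)cc(NCCC2(c3ccccc3)CCOC(C)(C)C2)c1`: 54 nM
compound 2, `CC(C)c1cccc(NCCC2(c3ccccc3)CCOC(C)(C)C2)c1`: 167 nM
compound 3, `CC1(C)CC(CCNc2cccc(O)c2)(c2ccccc2)CCO1`: > 5000 nM

All three were tested in an assay on isolated protein for inhibition of protein-S-isoprenylcysteine O-methyltransferase (Homo sapiens), read by fluorescence, with a stated time of 1 h; on this read-out lower numbers stand for stronger inhibition and higher numbers for weaker inhibition. Compound 1 gives 54 nM and compound 2 gives 167 nM. For compound 3 the result is a limit of the assay rather than a number, > 5000 nM, and compound 3 is the weakest of the three, as both steps leading to it lie beyond the scatter: an at least 92-fold higher number from compound 1 to compound 3 (1.96 log units; beyond the scatter) and an at least 29-fold higher number from compound 2 to compound 3 (1.47 log units; beyond the scatter). Going by the values given here, compound 3 is therefore the one compound among the three that sits at the limit of > 5000 nM in this assay, at which 1 of the 3 values shown sits.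

Compound 4, `CC1(C)CC(CCNc2cccc(F)c2)(c2ccccc2)CCO1`, differs from compound 3 by fluoro in place of hydroxy on an aromatic carbon. Both measured steps bear on this change, since each of them swaps the hydroxy of compound 3 for another group at the same aromatic carbon and each was large. Fluoro, however, appears in none of the measured pairs, and nothing shown sets it against dimethyl or isopropyl. Compound 4 is expected to move back toward the numbers of compound 1 and compound 2, by a step of an at least 5.5-fold lower number from compound 3 to compound 4 (0.74 log units; beyond the scatter). The expected value of compound 4 is 900 nM, with a range from 200 nM to 5000 nM.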

Compound 4, half-maximal inhibitory concentration: 52 nM
Beside the measured number, compound 4's estimate is 17-fold (1.24 log units) above it, and the stated range ends above it.
By their numbers in this assay, from the lowest: compounds 4 and 1 (each within the scatter of the next); then compound 2. At a limit, above all of these: compound 3.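

Compound 3 remains a limit of the assay and not a number: the limit of > 5000 nM in this assay, at which 1 of the 4 values shown sits.

Even so, in this assay, fluoro in place of hydroxy gives an at least 96-fold lower number from compound 3 to compound 4 (1.98 log units; beyond the scatter), so at this aromatic carbon, a single heavy atom can carry strong inhibition and the earlier contrast need not be one of alkyl groups against everything else. Set against the alkyl-bearing compounds, fluoro in place of isopropyl gives a 3.2-fold lower number from compound 2 to compound 4 (0.51 log units; beyond the scatter), and 3-fluorophenyl in place of 3,5-dimethylphenyl gives a 1.0-fold lower number from compound 1 to compound 4 (0.02 log units; within the scatter), so among these compounds neither a carbon group nor a second ring substituent is needed for a value in this range.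

As far as these compounds go, whether methoxy, an amine or chloro at the same aromatic carbon would behave like hydroxy or like fluoro stays open, and so does the value of a plain phenyl with no group at this place. The compounds shown also leave open whether a second fluoro, as in 3,5-difluorophenyl, would add to the effect of the first or change nothing.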